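The source may hold more compounds than are shown below. What is called first, only, known or untested is meant among the compounds shown, and "the series" means these compounds.

Of the compounds shown here, three sharing one core have been measured in an assay on isolated protein for inhibition of serine/threonine-protein kinase TNNI3K (Homo sapiens); on this read-out higher numbers stand for weaker inhibition and lower numbers for stronger inhibition. Compound 1 `CCNc1cc(Oc2ccc(NC(=O)Nc3cccc(C(F)(F)F)c3)cc2)ncn1` gives 25 nM. Compound 2 `CNc1cc(Oc2ccc(NC(=O)Nc3cccc(C(F)(F)F)c3)cc2Cl)ncn1` gives 50 nM. Compound 3 `CNc1cc(Oc2ccc(NC(=O)Nc3cccc(C(F)(F)F)c3)cc2)ncn1` gives 40 nM. Compound 3 sits close to both of the others: the step of a 1.3-fold lower number from compound 2 to compound 3 (0.10 log units; within the scatter) and the step of a 1.6-fold higher number from compound 1 to compound 3 (0.20 log units; within the scatter) are each within the scatter, so the three numbers cannot be told apart with any confidence.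

Compound 4 `CCCNc1cc(Oc2ccc(NC(=O)Nc3cccc(C(F)(F)F)c3)cc2)ncn1` has not yet been measured. It differs from compound 3 by ethyl in place of hydrogen on a saturated chain carbon bound to a nitrogen on an aromatic ring. Within the data shown here, the one measured step that bears on this place is a 1.6-fold higher number from compound 1 to compound 3 (0.20 log units; within the scatter), where the chain on that nitrogen was shortened and the number moved by an amount within the scatter. Lengthening the chain at the same place, from methyl to propyl, is therefore expected to move the number only a little, if at all, perhaps toward a lower number such as compound 1 shows with 25 nM, but not beyond the scatter. The expected step is a 1.4-fold lower number from compound 3 to compound 4 (0.15 log units; within the scatter). Compound 4 is estimated at 28 nM, with a range from 10 nM to 70 nM.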

Compound 4, half-maximal inhibitory concentration: 32 nM
Compound 4: the middle estimate sits 1.1-fold (0.06 log units) below what was measured; measured number inside the range.
By their numbers in this assay, from the lowest: compounds 1, 4, 3 and 2 (each within the scatter of the next).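

In this assay, among these compounds, the new compound widens what can be said about the chain on this nitrogen: the earlier compounds offered a single step of one carbon, whereas here ethyl in place of hydrogen, which turns methylamino into propylamino, gives a 1.3-fold lower number from compound 3 to compound 4 (0.10 log units; within the scatter). A change of one carbon at the far end of the chain gives a 1.3-fold higher number from compound 1 to compound 4 (0.11 log units; within the scatter), so the methyl, ethyl and propyl chains on this nitrogen, all on the same shared core, give numbers that cannot be told apart, and no trend with chain length can be read from compounds 1, 3 and 4. Nothing at hand explains why these chains sit so close together.

On these data alone, it remains open whether a longer chain such as hexyl, a branched group such as isopropyl, or a chain ending in an amine or a carboxylic acid would stay within the scatter of these numbers or move clearly away from them. The chloro group of compound 2 is also shown only with methylamino, so its pairing with propylamino is an open question.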